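Methoxy on the Benzothiazole of a Pyrazole Carboxamide

The source may hold more compounds than are shown below. What is called first, only, known or untested is meant among the compounds shown, and "the series" means these compounds.

The study measures an ADME assay on HEK-293T cells (Homo sapiens) for cytotoxicity, read by MTT assay, with a stated time of 72 h (a higher number here means a weaker inhibitor, a lower number a stronger inhibitor), on two pyrazole carboxamides and leaves a third open. Compound 1 `COc1ccc2nc(NC(=O)c3cn(-c4ccccc4)nc3-c3ccc(F)cc3)sc2c1` carries a 6-methoxy-1,3-benzothiazol-2-yl amide and a fluorophenyl on the pyrazole. In this assay compound 1 gives only a limit, > 50000 nM. For the measured compounds named here, compound 2 `COc1ccc(-c2nn(-c3ccccc3)cc2C(=O)Nc2nc3ccccc3s2)cc1` carries the unsubstituted 1,3-benzothiazol-2-yl amide and a methoxyphenyl on the pyrazole, and in this assay compound 2 gives 18900 nM, the only full number among the two values shown. The other value, that of compound 1, is a limit (the limit of > 50000 nM in this assay, at which 1 of the 2 values shown sits). Compound 3 `COc1ccc(-c2nn(-c3ccccc3)cc2C(=O)Nc2nc3ccc(OC)cc3s2)cc1` is compound 2 with a single change: methoxy in place of hydrogen on an aromatic carbon. Going by the values given here, no step between two measured compounds is available for this change, so its size can only be expected. Given that compound 1, which also carries the 6-methoxy-1,3-benzothiazol-2-yl amide, reaches > 50000 nM, the step is expected to be toward a higher number, by a 2.1-fold higher number from compound 2 to compound 3 (0.33 log units; beyond the scatter). Compound 3 is therefore estimated at 40000 nM, somewhere between 15000 nM and 100000 nM, with a fair chance that this assay again reports only a limit.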

Compound 3, half-maximal inhibitory concentration: > 50000 nM
Compound 3 was reported as a limit; the forecaster's own chance of this, stated with the estimate: 55%; at least 1.2-fold (0.09 log units) between middle value and limit.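

In this assay, for the compounds shown here, the change from 1,3-benzothiazol-2-yl to 6-methoxy-1,3-benzothiazol-2-yl now has a measured lower bound, which the earlier compounds could not give: an at least 2.6-fold higher number from compound 2 to compound 3 (0.42 log units; beyond the scatter). This pair differs in that one place only, so the shift to a higher number belongs to the methoxy on the aromatic carbon, with the methoxyphenyl on the pyrazole held constant. The step between compound 1 and compound 3, methoxy in place of fluoro, cannot be read, as both values are limits: the limit of > 50000 nM in this assay, at which 2 of the 3 values shown sit.

From the compounds shown here alone, how far compound 3 lies past its limit stays open, and so does the full size of the step. Also open, going by these compounds, is whether an amine or a carboxylic acid in place of the methoxy would give a full number in this assay.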